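This account rests on a few compounds, and the source may have more. Where it says the series, first, only, none or still open, it means among the compounds named here.

Compound 1 `C/C(=C\CC/C(C)=C/CC[C@@H]1[C@@]2(C)CCC(=O)C(C)(C)[C@H]2CC[C@@]1(C)O)CC/C=C(\C)C(=O)OCc1cn(-c2ccc(F)c(Cl)c2)nn1` gives > 150000 nM in an ADME assay on L132 cells (Homo sapiens) for cytotoxicity, read by MTT assay, with a stated time of 48 h (a lower number here means a stronger inhibitor, a higher number a weaker inhibitor), which is a limit of the assay.
Compound 2 `C/C(=C\CC/C(C)=C/CC[C@@H]1[C@@]2(C)CCC(=O)C(C)(C)[C@H]2CC[C@@]1(C)O)CC/C=C(\C)C(=O)OCc1cn(-c2ccc(F)cc2)nn1` gives > 150000 nM in this assay, again a limit of the assay.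
Compound 3 `C/C(=C\CC/C(C)=C/CC[C@@H]1[C@@]2(C)CCC(=O)C(C)(C)[C@H]2CC[C@@]1(C)O)CC/C=C(\C)C(=O)OCc1cn(-c2ccc(C(C)(C)C)cc2)nn1` gives 65800 nM in this assay.

Among the compounds with values here, compound 3 thus holds the only number among the three; the other two values sit at a limit (the limit of > 150000 nM in this assay, at which 2 of the 3 values shown sit). The step from compound 1 to compound 3 reads an at least 2.2-fold lower number from compound 1 to compound 3 (0.35 log units; beyond the scatter), and the step from compound 2 to compound 3 reads an at least 2.2-fold lower number from compound 2 to compound 3 (0.35 log units; beyond the scatter). The step from compound 1 to compound 2 is a step that the two limits leave unreadable from compound 1 to compound 2.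

Compound 4 `COc1ccc(-n2cc(COC(=O)/C(C)=C/CC/C(C)=C/CC/C(C)=C/CC[C@@H]3[C@@]4(C)CCC(=O)C(C)(C)[C@H]4CC[C@@]3(C)O)nn2)cc1` differs from compound 3 at one place: methoxy in place of tert-butyl on an aromatic carbon. Within the data shown here, the steps that bear on it are the two into compound 3, where tert-butyl entered and the number came down beyond the scatter. With tert-butyl leaving again, the number for compound 4 is expected to rise back toward the limit, an expected step of a 1.8-fold higher number from compound 3 to compound 4 (0.26 log units; within the scatter) in this assay. Compound 4 is therefore estimated at 120000 nM, with a range from 50000 nM to 300000 nM.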

Compound 4, half-maximal inhibitory concentration: > 150000 nM
Compound 4: a limit, no number; the forecaster's own chance of this, stated with the estimate: 45%; middle value at least 1.2-fold (0.09 log units) from the limit.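

In this assay, within the data shown here, methoxy on the aromatic carbon para to a large group gives an at least 2.2-fold higher number from compound 3 to compound 4 (0.35 log units; beyond the scatter), so the lower number of compound 3 now stands against an oxygen-bearing group as well as against the fluoro and chloro groups of the earlier compounds. Among the four compounds, only compound 3, with its tert-butyl, gives a number rather than a limit. The value of compound 4 is a limit and not a number, and the steps from compounds 1 and 2 to compound 4 cannot be read, as the value joins theirs: the limit of > 150000 nM in this assay, at which 3 of the 4 values shown sit.

The compounds shown leave open whether tert-butyl is alone in this effect or whether isopropyl, a longer alkyl chain or an amine at this place would also give a number. From the compounds shown here alone, how far compounds 1, 2 and 4 lie from one another also stays open.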